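A few compounds are considered here, and "the series" means these few. Any claim that something is new, unique, unknown or untested is made for them only; others in the source may bear on it.

Going by the values given here, in a functional assay on Huh-5-2 cells (Homo sapiens), read by MTT assay (on this read-out lower numbers stand for higher toxicity in this test and higher numbers for lower toxicity in this test), compound 1 (`CNC(=O)c1ccc(-c2ccc(Cl)cc2)c(COc2ccc(-c3nc4cc(C(=O)O)ccc4n3C3CCCCC3)cc2)c1`) gives 25000 nM and compound 2 (`CCCNC(=O)c1ccc(-c2ccc(Cl)cc2)c(COc2ccc(-c3nc4cc(C(=O)O)ccc4n3C3CCCCC3)c(F)c2)c1`) gives 24000 nM within the scatter of each other, so compound 2 sits level with the only other measured compound. Compound 3 (`CN(C)C(=O)c1ccc(-c2ccc(Cl)cc2)c(COc2ccc(-c3nc4cc(C(=O)O)ccc4n3C3CCCCC3)c(F)c2)c1`) differs from compound 2 by dimethylamino in place of propylamino on a carbonyl carbon. Among the compounds with values here, no measured step isolates this change, so no shift beyond the scatter, in either direction, is expected in this assay; the only guide is compound 2 at 24000 nM in that read-out. The expected change is small, a 1.0-fold higher number from compound 2 to compound 3 (0.02 log units; within the scatter) by this estimate. Compound 3 is estimated at 25000 nM (12000 nM to 50000 nM).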

Compound 3, half-maximal cytotoxic concentration: 26000 nM
For compound 3 the middle estimate is 1.0-fold (0.02 log units) below the measured one; the measured number falls inside the stated range.
By their numbers in this assay, from the lowest: compounds 2, 1 and 3 (each within the scatter of the next).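

In this assay dimethylamino in place of propylamino on a carbonyl carbon gives a 1.1-fold higher number from compound 2 to compound 3 (0.03 log units; within the scatter) as the first step read at this position. The amide hydrogen goes with this change, yet the read-out does not separate the two compounds, so on this carbonyl carbon neither the propylamino chain nor that hydrogen is needed to keep the number where it stands. No available evidence bears on this result.

As far as these compounds go, whether a longer chain or a morpholine on the same carbonyl carbon would move the number beyond the scatter remains open. A carboxylic acid or a basic amine at the end of that chain is equally untested in the compounds shown here.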